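Compound 2 to compound 3: phenyl for isopropyl

A few compounds are considered here, and "the series" means these few. Any claim that something is new, unique, unknown or untested is made for them only; others in the source may bear on it.

In a functional assay on HeLa cells (Homo sapiens) for cytotoxicity, read by MTT assay (on this read-out higher numbers stand for weaker inhibition and lower numbers for stronger inhibition), compound 2 (`CC(C)=CC[C@@H](OC(=O)CC(C)(O)C(C)C)C1=CC(=O)c2c(O)ccc(O)c2C1=O`) gives 27700 nM, the lower of two numbers, while compound 1 (`CC(C)=CC[C@@H](OC(=O)c1ccco1)C1=CC(=O)c2c(O)ccc(O)c2C1=O`) gives 80300 nM. Compound 3 (`CC(C)=CC[C@@H](OC(=O)CC(C)(O)c1ccccc1)C1=CC(=O)c2c(O)ccc(O)c2C1=O`) differs from compound 2 by phenyl in place of isopropyl on a saturated chain carbon bound to an oxygen on a saturated carbon and two saturated chain carbons, with phenyl in place of isopropyl on a saturated chain carbon. Among the compounds with values here, the only measured step, a 2.9-fold lower number from compound 1 to compound 2 (0.46 log units; beyond the scatter), was modest and replaced the whole group on a carbonyl carbon. The present change touches only part of that group. The expected step in this assay, a 1.1-fold higher number from compound 2 to compound 3 (0.03 log units; within the scatter), stays within the scatter. Compound 3 is estimated at 30000 nM, with an expected range of 12000 nM to 70000 nM.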

Compound 3, half-maximal inhibitory concentration: 85700 nM
Compound 3: middle estimate off by 2.9-fold (0.46 log units), on the low side, and the stated range ends below it.
By their numbers in this assay, from the lowest: compound 2; then compounds 1 and 3 (each within the scatter of the next).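

In this assay, this saturated chain carbon does not treat phenyl and isopropyl alike: a 3.1-fold higher number from compound 2 to compound 3 (0.49 log units; beyond the scatter). With phenyl in place, 2-hydroxy-2-phenylpropyl and furan-2-yl on the carbonyl carbon cannot be told apart: a 1.1-fold higher number from compound 1 to compound 3 (0.03 log units; within the scatter). No available evidence bears on the reason for this step.

The compounds shown leave open how a methyl, cyclohexyl or pyridin-3-yl group would read at this place. Also open, as far as these compounds go, is whether the hydroxy group on that carbon is needed for the level of compound 2.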